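Replacing 1H-pyrazol-1-yl with trifluoromethoxy near a solubility limit

A few compounds are considered here, and "the series" means these few. Any claim that something is new, unique, unknown or untested is made for them only; others in the source may bear on it.

Measured in a physicochemical assay for solubility, using the shake flask method, in simulated intestinal fluid, measured as kinetic solubility, with a stated time of 2 h, at 25 degrees C, at pH 6.5 (on this read-out lower numbers stand for lower solubility and higher numbers for higher solubility), so far:
- compound 1 `COC(=O)c1nc(C)c2c(c1N)C(=O)N(Cc1ccccc1)C2=O` gives 7400 nM
- compound 2 `CCCOC(=O)c1nc(C)c2c(c1N)C(=O)N(Cc1ccccc1)C2=O` gives < 5000 nM (a limit of the assay, not a number)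
- compound 3 `Cc1noc(-c2nc(C)c3c(c2N)C(=O)N(Cc2ccc(-n4cccn4)cc2)C3=O)n1` gives < 5000 nM (a limit of the assay, not a number)

Compound 3 has no exact number in this assay, since its < 5000 nM is only a limit. Compound 3 stands at the limit of < 5000 nM in this assay, at which 2 of the 3 values shown sit, so there is no firm starting point for the next step.

Compound 4 `Cc1noc(-c2nc(C)c3c(c2N)C(=O)N(Cc2ccc(OC(F)(F)F)cc2)C3=O)n1` differs from compound 3 in one place: trifluoromethoxy in place of 1H-pyrazol-1-yl on an aromatic carbon. Trifluoromethoxy takes the place of 1H-pyrazol-1-yl on an aromatic carbon of a six-membered aromatic ring of carbon only, para to a large group.

Going by the values given here, only one measured step is available as a guide, and it bears on this change only loosely. That step, an at least 1.4-fold lower number from compound 1 to compound 2 (0.17 log units; that floor lies within the scatter), puts ethyl in place of hydrogen on a different part of the molecule, and its floor lies within the scatter of repeat measurements. It gives no ground for expecting a change beyond the scatter in this assay, in either direction. The expected step is a step that the limit leaves unreadable from compound 3 to compound 4. Compound 4 is estimated at 3000 nM, with an expected range from 800 nM to 7000 nM.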

Compound 4, solubility: < 5000 nM
Compound 4: no number, only a limit (the forecaster's own chance of this, stated with the estimate: 75%); the middle value does not contradict the limit.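

In this assay compound 3 and compound 4 both carry only a limit, not a number, so no step can be read between them: the limit of < 5000 nM in this assay, at which 3 of the 4 values shown sit.

The compounds shown leave open whether trifluoromethoxy in place of 1H-pyrazol-1-yl changes the read-out at all, and, if it does, in which direction and by how much.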